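Aryl swap on the saturated ring carbon: outlook for compound 3

The source may report more compounds than this note shows. Statements on the series, on what has been measured and on what is new or still open speak of the compounds shown alone.

Measured so far:
compound 1, `COc1ccc(C2CC(C3C(=O)c4ccccc4C3=O)=NC(=O)N2)cc1`: 22%
compound 2, `O=C1N=C(C2C(=O)c3ccccc3C2=O)CC(c2cccc([N+](=O)[O-])c2)N1`: 27%

In a functional assay on the whole organism for inhibition, with Rattus norvegicus as the target, read by paw edema, with stated times of 30 min and 1 h, at a dose of 10 mg/kg by the oral route (on this read-out lower numbers stand for less inhibition and higher numbers for more inhibition at the one dose given (going by the name of the read-out)), compound 1 gives 22% and compound 2 gives 27%. Within the data shown here, compound 2 stands together with compound 1 within the scatter: the only measured step, a number 5 percentage points higher from compound 1 to compound 2 (within the scatter), cannot be told from noise, so the two numbers count as one level rather than a trend.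

Compound 3, `O=C1N=C(C2C(=O)c3ccccc3C2=O)CC(c2ccccc2O)N1`, differs from compound 2 by 2-hydroxyphenyl in place of 3-nitrophenyl on a saturated ring carbon. Among the measured compounds shown here, the single step on record, from compound 1 to compound 2, bears on this change directly, since it is also a swap of the aryl group on the same saturated ring carbon, and it stayed within the scatter. Nothing measured here shows that exchanging one aryl group for another at this position moves the read-out beyond the scatter, and no information about a hydroxyl-bearing aryl group is available.

Compound 3 is therefore expected to give 25%, within a range of 10% to 40%. The step this estimate means, a number 2 percentage points lower from compound 2 to compound 3 (within the scatter), is expected to lie within the scatter.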

Compound 3, a percentage reported as inhibition, in the whole organism at one dose (the size of the read-out at that dose, not a potency): 24%
For compound 3 the middle estimate is 1 percentage points above the measured one; the measured number falls inside the stated range.
By their numbers in this assay, from the lowest: compounds 1, 3 and 2 (each within the scatter of the next).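

In this assay, 2-hydroxyphenyl in place of 3-nitrophenyl on the saturated ring carbon gives a number 3 percentage points lower from compound 2 to compound 3 (within the scatter), and 2-hydroxyphenyl in place of 4-methoxyphenyl at the same carbon gives a number 2 percentage points higher from compound 1 to compound 3 (within the scatter). The earlier compounds shown here offered a single aryl swap at this position; there are now three aryl groups, including one bearing a hydroxyl, and no exchange among them moves the read-out beyond the scatter, so compounds 1, 2 and 3 count as one level. No other measurement on these compounds bears on this result.

The compounds shown leave open whether a group of another kind on this carbon, such as a longer alkyl chain, or an aryl group carrying an amine or a carboxylic acid, would separate from this level. They also leave open whether a change elsewhere on the shared core would do so, and whether the level seen at this one dose holds at other doses.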